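Swapping 2,5-dioxoimidazolidin-1-yl for 1H-1,2,3-triazol-1-yl

The source may hold more compounds than are shown below. What is called first, only, known or untested is meant among the compounds shown, and "the series" means these compounds.

Compound 1 `O=C1O[C@@H](CN2CCCCC2)CN1c1ccc(-n2cc(-c3ccccn3)cn2)c(F)c1`: in an ADME assay on L02 cells (Homo sapiens) for cytotoxicity, read by MTT assay, with a stated time of 48 h (on this read-out higher numbers stand for weaker inhibition and lower numbers for stronger inhibition), compound 1 gives > 400 ug/mL, a limit of the assay.
Compound 2 `O=C1CCC(=O)N1C[C@H]1CN(c2ccc(-n3cc(-c4ccccn4)cn3)c(F)c2)C(=O)O1`: in this assay compound 2 gives > 400 ug/mL, also a limit.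
Compound 3 `O=C1CNC(=O)N1C[C@H]1CN(c2ccc(-n3cc(-c4ccccn4)cn3)c(F)c2)C(=O)O1`: in this assay compound 3 gives > 400 ug/mL, again a limit.

Compound 3 therefore stands at the limit, as do all three measured compounds (the limit of > 400 ug/mL in this assay, at which 3 of the 3 values shown sit). The steps a step that the two limits leave unreadable from compound 1 to compound 3 and a step that the two limits leave unreadable from compound 2 to compound 3 bear on it, yet neither has a readable size. Compound 4 `O=C1O[C@@H](Cn2ccnn2)CN1c1ccc(-n2cc(-c3ccccn3)cn2)c(F)c1` differs from compound 3 as follows: 1H-1,2,3-triazol-1-yl in place of 2,5-dioxoimidazolidin-1-yl on a saturated chain carbon bound to a saturated ring carbon. With no readable step to go by, no change beyond the scatter is expected, and the step of a number no higher from compound 3 to compound 4 (the limit leaves the size open) is estimated from the limit alone. Compound 4 is expected to give about 400 ug/mL, within 200 ug/mL to 800 ug/mL.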

Compound 4, half-maximal inhibitory concentration: 49 ug/mL
Compound 4: the middle estimate sits 8.2-fold (0.91 log units) above what was measured; measured number outside the range, below it.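

At this place, on a saturated chain carbon bound to a saturated ring carbon, the choice of group can move the read-out in this assay: 1H-1,2,3-triazol-1-yl brings an at least 8.1-fold lower number from compound 3 to compound 4 (0.91 log units; beyond the scatter), an at least 8.1-fold lower number from compound 2 to compound 4 (0.91 log units; beyond the scatter) and an at least 8.1-fold lower number from compound 1 to compound 4 (0.91 log units; beyond the scatter). A lower number here means stronger inhibition, so compound 4 is the only compound shown with a readable cytotoxicity value. Each step gives only a minimum size because the other compounds sit at a limit: the limit of > 400 ug/mL in this assay, at which 3 of the 4 values shown sit.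

The compounds shown leave open whether the effect belongs to 1H-1,2,3-triazol-1-yl alone or extends to other aromatic rings, such as 1H-imidazol-1-yl or 1H-tetrazol-1-yl. On these data alone, how a simple amine would read at this place also remains open.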